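Hydrazone aryl swap: cytotoxicity outlook for compound 3

The source may report more compounds than this note shows. Statements on the series, on what has been measured and on what is new or still open speak of the compounds shown alone.

Measured so far in an ADME assay on THP-1 cells (Homo sapiens) for cytotoxicity; a higher number here means a weaker inhibitor, a lower number a stronger inhibitor:
compound 1 `COc1ccccc1-c1nnc(-c2ccc(C(=O)N/N=C/c3cccnc3)cc2)o1` — 167000 nM
compound 2 `COc1ccccc1-c1nnc(-c2ccc(C(=O)N/N=C/c3ccccn3)cc2)o1` — 67000 nM

Among the measured compounds shown here, compound 2 stands at the lowest of the two numbers in this assay; the only neighbour is compound 1, which gives the higher number. For the measured compounds named here, the single measured step, a 2.5-fold lower number from compound 1 to compound 2 (0.40 log units; beyond the scatter), is modest but beyond the scatter.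

Compound 3 `COc1ccc(/C=N/NC(=O)c2ccc(-c3nnc(-c4ccccc4OC)o3)cc2)c(O)c1` differs from compound 2 in one place: 2-hydroxy-4-methoxyphenyl in place of pyridin-2-yl on a carbon with a double bond to nitrogen. Going by the values given here, the one measured step bears on it only loosely, since that step exchanged two pyridyl isomers at the same carbon, whereas here a pyridyl gives way to a phenyl carrying hydroxy and methoxy groups. Among the compounds with values here, no measured pair tracks such a change, so the expectation leans mainly on the small size of the one known step at this position.

For compound 3 the expected step is a 1.0-fold higher number from compound 2 to compound 3 (0.02 log units; within the scatter), that is, no movement beyond the scatter with a wide margin either way. The estimate for compound 3 in this assay is therefore 70000 nM, within 20000 nM to 250000 nM.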

Compound 3, half-maximal inhibitory concentration: 308000 nM
For compound 3 the middle estimate is 4.4-fold (0.64 log units) below the measured one, and the stated range ends below it.
By their numbers in this assay, from the lowest: compound 2; then compounds 1 and 3 (each within the scatter of the next).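

In this assay, the carbon with a double bond to nitrogen now shows a response to more than an exchange of pyridyl isomers: placing 2-hydroxy-4-methoxyphenyl there in place of pyridin-2-yl gives a 4.6-fold higher number from compound 2 to compound 3 (0.66 log units; beyond the scatter). The same group in place of pyridin-3-yl gives a 1.8-fold higher number from compound 1 to compound 3 (0.27 log units; within the scatter), so among the three compounds shown, compound 2 alone stands apart, with steps beyond the scatter to both others, and the pyridin-2-yl compound remains the strongest inhibitor in this assay. Nothing available bears on what lies behind these steps.

As far as these compounds go, it remains open whether the hydroxy group, the methoxy group or the carbon-only aromatic ring itself carries the step from pyridin-2-yl, since 2-hydroxy-4-methoxyphenyl brings these changes in together. From the compounds shown here alone, it is also open how this position would respond to an unsubstituted phenyl, or to a phenyl bearing an amine or a carboxylic acid, and whether any such group would come close to compound 2 or stay with compound 1 and compound 3.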